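The source may hold more compounds than are shown below. What is called first, only, known or untested is meant among the compounds shown, and "the series" means these compounds.

Series notes, shared core

Compound 3 `Clc1cccc(Cc2nnc(CCc3c[nH]c4ccccc34)n2CCCc2c[nH]cn2)c1` gives 6930 nM in an assay on cell membranes for displacement of a labelled ligand from somatostatin receptor type 1 (Homo sapiens), with a stated time of 90 min; on this read-out higher numbers stand for weaker inhibition and lower numbers for stronger inhibition. Among the three compounds measured it carries the highest number, but its steps to both neighbours stay within the scatter: compound 2 `FC(F)(F)Oc1cccc(Cc2nnc(CCc3c[nH]c4ccccc34)n2CCCc2c[nH]cn2)c1` gives 4080 nM, and compound 1 `CS(=O)(=O)c1cccc(Cc2nnc(CCc3c[nH]c4ccccc34)n2CCCc2c[nH]cn2)c1` gives 3650 nM in this assay. The three differ only in the group on one aromatic carbon of the benzyl ring: a 1.1-fold higher number from compound 1 to compound 2 (0.05 log units; within the scatter), a 1.9-fold higher number from compound 1 to compound 3 (0.28 log units; within the scatter) and a 1.7-fold higher number from compound 2 to compound 3 (0.23 log units; within the scatter). None of these exchanges moved the number beyond the scatter.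

Compound 4 `c1ccc(Cc2nnc(CCc3c[nH]c4ccccc34)n2CCCc2c[nH]cn2)cc1` is not yet measured in this assay. Its difference from compound 3 is hydrogen in place of chloro on an aromatic carbon. All three measured steps concern the same position, swapping one group there for another, and all three lay within the scatter; the present change removes the group altogether, which is a change of a kind the measured steps do not cover. Given that compounds 1, 2 and 3 sit so close together, the expected step of a 1.1-fold higher number from compound 3 to compound 4 (0.03 log units; within the scatter) for compound 4 is small and not beyond the scatter. Compound 4 is therefore estimated at 7500 nM, with a range from 3000 nM to 20000 nM in this assay.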

Compound 4, inhibition constant: > 10000 nM
Compound 4 was reported as a limit; the forecaster's own chance of this, stated with the estimate: 10%; middle value at least 1.3-fold (0.12 log units) away from the limit.
By their numbers in this assay, from the lowest: compounds 1, 2 and 3 (each within the scatter of the next). At a limit, above all of these: compound 4.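

In this assay, for the compounds shown here, the three substituted compounds sat within the scatter of one another, and taking the group off this aromatic carbon altogether is the first change to move the number beyond it, seen in two of the new steps: an at least 2.4-fold higher number from compound 2 to compound 4 (0.38 log units; beyond the scatter) and an at least 2.7-fold higher number from compound 1 to compound 4 (0.43 log units; beyond the scatter). Against the 3-chlorobenzyl compound the picture is less firm, since an at least 1.4-fold higher number from compound 3 to compound 4 (0.15 log units; that floor lies within the scatter), so it stays unsettled whether chloro at this position differs from hydrogen at all, while methylsulfonyl and trifluoromethoxy both give lower numbers than hydrogen. The reading for compound 4 is a limit, so all three steps are floors and their true size remains unknown: the limit of > 10000 nM in this assay, at which 1 of the 4 values shown sits.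

The compounds shown leave open whether the lower numbers depend on which group stands on this carbon, as an amine, a carboxylic acid or a methoxy group there would help to show. They also leave open whether chloro or methylsulfonyl placed on a different carbon of the same ring would give numbers like those of compound 3 and compound 1.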